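Spirocyclic sulfonamides: acetamido replacing the cyclic urea

The source may hold more compounds than are shown below. What is called first, only, known or untested is meant among the compounds shown, and "the series" means these compounds.

Among the measured compounds shown here, compound 2 `Cc1cc(N2CCNC2=O)cc(C)c1CCS(=O)(=O)N1CCC2(CC1)N=C(C1CCCCC1)NC2=O` gives 3.4 uL/min in an ADME assay on microsomes from liver (Homo sapiens) for metabolic stability, read by LC-MS, with NADPH named in the record, with a stated time of 30 min, tested at 1 uM, in the absence of a further agent (on this read-out higher numbers stand for fast clearance and lower numbers for slow clearance), the highest of the two numbers measured so far; compound 1 `Cc1cc(N(C)C(N)=O)cc(C)c1CCS(=O)(=O)N1CCC2(CC1)N=C([C@H]1CC[C@H](C)CC1)NC2=O` gives 0.14 uL/min, a gap that lies beyond the scatter. Compound 3 `CC(=O)Nc1cc(C)c(CCS(=O)(=O)N2CCC3(CC2)N=C(C2CCCCC2)NC3=O)c(C)c1` has not been measured. It differs from compound 2 in a single place: acetamido in place of 2-oxoimidazolidin-1-yl on an aromatic carbon. For the measured compounds named here, no measured pair shows this change, so the expected step is small and without a firm direction, probably within the scatter, namely a 1.4-fold lower number from compound 2 to compound 3 (0.13 log units; within the scatter). In this assay compound 3 is therefore estimated at 2.5 uL/min, within a range of 0.8 uL/min to 8 uL/min.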

Compound 3, intrinsic clearance in a liver preparation (reported as CLH), per the amount of preparation that the assay uses: 18 uL/min
Compound 3: the middle estimate sits 7.2-fold (0.86 log units) below what was measured, outside the stated range (above it).
By their numbers in this assay, from the lowest: compound 1; then compound 2; then compound 3.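

At this aromatic carbon, para to a large group, the two groups are not interchangeable in this assay: acetamido in place of 2-oxoimidazolidin-1-yl gives a 5.3-fold higher number from compound 2 to compound 3 (0.72 log units; beyond the scatter). The ring-bearing group therefore goes with the lower number, although both groups carry the same counts of hydrogen-bond donors and acceptors. Nothing on hand accounts for the step.

Open, from the compounds shown here alone, is whether the ring itself or the group's size goes with this difference. Also open, going by these compounds, is how a carboxylic acid or an amine on the same aromatic carbon would read.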